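One Aryl Swap, Two Cores, Vero Cell Cytotoxicity

A few compounds are considered here, and "the series" means these few. Any claim that something is new, unique, unknown or untested is made for them only; others in the source may bear on it.

Three compounds carrying a 1-benzofuran-2-yl group on a five-membered non-aromatic ring with 2 nitrogen were tested in an ADME assay on Vero cells (Chlorocebus sabaeus) for cytotoxicity, read by MTT assay, with a stated time of 72 h; on this read-out lower numbers stand for stronger inhibition and higher numbers for weaker inhibition. Compound 1 `COc1ccccc1C1CC(c2cc3ccccc3o2)=NN1C(=O)c1ccncc1` gives > 202000 nM, which is a limit of the assay rather than a number. Compound 2 `CN(C)c1ccc(C2CC(c3cc4ccccc4o3)=NN2C(=O)c2ccncc2)cc1` likewise reaches only a limit, > 210000 nM. The two differ by 4-(dimethylamino)phenyl in place of 2-methoxyphenyl on a saturated ring carbon. Because both values sit at limits shown by the limit of > 202000 nM in this assay, at which 1 of the 3 values shown sits, and (the limit of > 210000 nM in this assay, at which 1 of the 3 values shown sits), the step that the two limits leave unreadable from compound 1 to compound 2 cannot be read.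

Compound 3 `CCn1cc(C(=O)N2N=C(c3cc4ccccc4o3)CC2c2ccccc2OC)c(=O)c2ccc(C)nc21` has a different core; how its core differs from that of compound 1 is not broken down here. In this assay compound 3 gives > 187000 nM, again a limit. Compound 4 `CCn1cc(C(=O)N2N=C(c3cc4ccccc4o3)CC2c2ccc(N(C)C)cc2)c(=O)c2ccc(C)nc21` differs from compound 3 by 4-(dimethylamino)phenyl in place of 2-methoxyphenyl on a saturated ring carbon. This is the same kind of change as that between compound 1 and compound 2, but the surroundings differ: in compound 1 the changed carbon is next to the ring atom that bears a (pyridin-4-yl)carbonyl group, whereas in compound 3 it is next to the ring atom that bears a large group.

The expected step that the limit leaves unreadable from compound 3 to compound 4 is set beside the measured step that the two limits leave unreadable from compound 1 to compound 2, and it rests on the limit shown by the limit of > 187000 nM in this assay, at which 1 of the 3 values shown sits, which leaves no movement to read. Compound 4 is therefore expected to give about 250000 nM. For compound 4 the estimated range runs from 150000 nM to 600000 nM, and most likely only a limit will again be reported.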

Compound 4, half-maximal inhibitory concentration: > 206000 nM
Compound 4: a limit, no number; the forecaster's own chance of this, stated with the estimate: 85%; the middle value lies beyond the limit too.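

In this assay compound 4 gives > 206000 nM, which is a limit of the assay and not a number. Compound 3 also sits at a limit, and the step from it to compound 4 cannot be read. The compounds shown leave open whether 4-(dimethylamino)phenyl in place of 2-methoxyphenyl changes the cytotoxicity at all, and whether it would act alike on both cores.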